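Swapping methoxy for iodo on an aromatic ring

The source may hold more compounds than are shown below. What is called first, only, known or untested is meant among the compounds shown, and "the series" means these compounds.

In a functional assay on MCF7 cells (Homo sapiens) for inhibition, read by sulforhodamine B assay (a higher number here means a weaker inhibitor, a lower number a stronger inhibitor), compound 1 (`CCOc1ccc(NC2=CC(=O)c3nc4n(c3C2=O)[C@H]2OC[C@@H](O)[C@H]2OC4)cc1`) gives 1430 nM and compound 2 (`COc1ccc(NC2=CC(=O)c3nc4n(c3C2=O)[C@H]2OC[C@@H](O)[C@H]2OC4)cc1`) gives 5420 nM as its result. That leaves compound 2 with the higher of the two numbers, which makes it the weaker inhibitor of the pair.

The next compound to consider is compound 3 (`O=C1C=C(Nc2ccc(I)cc2)C(=O)c2c1nc1n2[C@H]2OC[C@@H](O)[C@H]2OC1`). It keeps the shared core but carries iodo in place of methoxy on an aromatic carbon, para to a large group (iodo in place of methoxy on an aromatic carbon). For the measured compounds named here, the one measured step that bears on this change involves the same group: a 3.8-fold higher number from compound 1 to compound 2 (0.58 log units; beyond the scatter) with hydrogen in place of methyl on the chain. A single step says little about iodo, which has not yet been tested on this core, so any forecast is loose. Going by that step alone, a move of similar or smaller size is expected in this assay and toward a lower number. The estimated change is a 2.2-fold lower number from compound 2 to compound 3 (0.34 log units; beyond the scatter) on this reasoning. For compound 3 the expected value is 2500 nM within a range of 700 nM to 9000 nM overall.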

Compound 3, half-maximal inhibitory concentration: 2230 nM
Compound 3: middle estimate off by 1.1-fold (0.05 log units), on the high side, and the stated range covers the measured number.
By their numbers in this assay, from the lowest: compounds 1 and 3 (each within the scatter of the next); then compound 2.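

Until now the only change at this place on the aromatic ring lay within an oxygen-linked chain, and compound 3 is the first of these compounds to carry a group with no oxygen there: in this assay iodo in place of methoxy gives a 2.4-fold lower number from compound 2 to compound 3 (0.39 log units; beyond the scatter) and so the swap moves the result beyond the scatter. Set against the ethoxy group of compound 1, iodo gives a 1.6-fold higher number from compound 1 to compound 3 (0.19 log units; within the scatter) and so these two groups cannot be told apart in this assay despite being quite different groups. An oxygen joined to the ring at this place is therefore not required to reach the level of compound 1, and among these three compounds it is the methoxy group of compound 2 that stands apart as the weakest.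

Going by these compounds, whether chloro, a carboxylic acid or a longer chain such as propoxy would stay in this range at this place remains open. Nothing available here explains why iodo and ethoxy land together or why methoxy falls behind them.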